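Swapping the Aryl Group on the Ring Nitrogen

This account rests on a few compounds, and the source may have more. Where it says the series, first, only, none or still open, it means among the compounds named here.

Of the compounds shown here, three sharing one core have been measured in a functional assay, read by spectrophotometry, with a stated time of 2 h, tested at 2.5 mg/mL; on this read-out higher numbers stand for a stronger effect at the one concentration tested and lower numbers for a weaker effect. Compound 1 `CC(C)[C@@H]1CC[C@@H](C)C[C@@]12N(C)C(=O)[C@@H]1[C@H]3C(=O)N(c4ccccc4)C(=O)[C@H]3ON12` gives 58.6%, compound 2 `CC(C)[C@@H]1CC[C@@H](C)C[C@@]12N(C)C(=O)[C@@H]1[C@H]3C(=O)N(c4ccc(Cl)cc4)C(=O)[C@H]3ON12` gives 60.1%, and compound 3 `COc1ccc(N2C(=O)[C@H]3[C@H](ON4[C@@H]3C(=O)N(C)[C@@]43C[C@H](C)CC[C@H]3C(C)C)C2=O)cc1` gives 71.5%, the highest of the three, with its steps to both others beyond the scatter. The step of a number 1.5 percentage points higher from compound 1 to compound 2 (within the scatter) lies within the scatter. Compound 4 `Cc1cccc(N2C(=O)[C@H]3[C@H](ON4[C@@H]3C(=O)N(C)[C@@]43C[C@H](C)CC[C@H]3C(C)C)C2=O)c1` carries the change (3-methylphenyl in place of 4-methoxyphenyl on an amide-type nitrogen in a ring). Going by the values given here, the steps that bear on this change are the two that brought methoxy in, a number 12.9 percentage points higher from compound 1 to compound 3 (beyond the scatter) and a number 11.4 percentage points higher from compound 2 to compound 3 (beyond the scatter), both modest gains; taking methoxy away again is expected to reverse part of that. In this assay a modest drop is therefore expected, a number 9.5 percentage points lower from compound 3 to compound 4 (within the scatter). Compound 4 is estimated at 62%, with a range from 50% to 74%.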

Compound 4, a percentage reported as activity, at one concentration (the size of the read-out at that concentration, not a potency): 47.7%
Compound 4: the middle estimate sits 14.3 percentage points above what was measured; measured number outside the range, below it.
By their numbers in this assay, from the lowest: compound 4; then compounds 1 and 2 (each within the scatter of the next); then compound 3.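

In this assay, the aryl group on this ring nitrogen can also lose activity against plain phenyl, since methyl on the aromatic carbon gives a number 10.9 percentage points lower from compound 1 to compound 4 (beyond the scatter), so the 3-methylphenyl group does more than give back the methoxy gain. Replacing the other aryl groups gives a number 23.8 percentage points lower from compound 3 to compound 4 (beyond the scatter) and a number 12.4 percentage points lower from compound 2 to compound 4 (beyond the scatter), which shows that substitution on this aryl ring can move the number either way. No measurement here accounts for the drop. The compounds shown leave open whether the difference follows the group or its place on the ring, which 4-methylphenyl and 3-methoxyphenyl would separate. On these data alone, how an aminophenyl group would read also remains open.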